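Pyrazole carbamate series: cyano on the pyrazole ring

The compounds below may be only part of what the source reports. "The series", "measured", "known", "first", "only" and "open" are said of these compounds alone.

Compound 1 `CN(CCN(C)C(=O)n1cccn1)Cc1ccc(OCc2ccccc2)cc1` in an assay on membranes from brain for binding affinity to Monoacylglycerol lipase ABHD6 (Mus musculus), read by fluorescence, with stated times of 1 h and 30 min (on this read-out lower numbers stand for stronger inhibition and higher numbers for weaker inhibition), gives 530 nM. Compound 2 `CN(CCN(C)C(=O)n1cc(C#N)cn1)Cc1ccc(OCc2ccccc2)cc1` in this assay gives 320 nM. The change between them is cyano in place of hydrogen on an aromatic carbon, and it gave a 1.7-fold lower number from compound 1 to compound 2 (0.22 log units; within the scatter).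

Compound 3 `O=C(N1CCN(C(c2ccc(OCc3ccccc3)cc2)c2ccc(OCc3ccccc3)cc2)CC1)n1cccn1` carries a different core; the difference between the cores of compound 1 and compound 3 is not broken down here. In this assay compound 3 gives only a limit of the assay, > 100000 nM. That is the limit of > 100000 nM in this assay, at which 1 of the 3 values shown sits.

Compound 4 `N#Cc1cnn(C(=O)N2CCN(C(c3ccc(OCc4ccccc4)cc3)c3ccc(OCc4ccccc4)cc3)CC2)c1` is not yet measured. It differs from compound 3 by cyano in place of hydrogen on an aromatic carbon, the same change as from compound 1 to compound 2, on the same place in the five-membered aromatic ring with 2 nitrogen.

For compound 4 a step of a number no higher from compound 3 to compound 4 (the limit leaves the size open) is expected, because a 1.7-fold lower number from compound 1 to compound 2 (0.22 log units; within the scatter) stayed within the scatter. The estimate for compound 4 in this assay is 100000 nM, with an expected range from 30000 nM to 300000 nM, and the assay is expected most likely to return only a limit again.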

Compound 4, half-maximal inhibitory concentration: 130000 nM
Compound 4: the middle estimate sits 1.3-fold (0.11 log units) below what was measured, within the range that was stated.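

No step from compound 3 to compound 4 can be read in this assay, because compound 3 stands only at a limit of the assay: the limit of > 100000 nM in this assay, at which 1 of the 4 values shown sits.

The compounds shown leave open whether cyano in place of hydrogen shifts the number at all on the core of compound 3, and which part of that core separates it from compound 1.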